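A few compounds are considered here, and "the series" means these few. Any claim that something is new, unique, unknown or untested is made for them only; others in the source may bear on it.

The measured compounds so far:

Compound 1, `CC(NC(=O)NS(=O)(=O)c1ccc(Cl)cc1)c1cc(Br)ccc1OCc1ccccc1`, gives 57500 nM.
Compound 2, `CC(NC(=O)NS(=O)(=O)c1ccccc1)c1cc(Br)ccc1OCc1ccccc1`, gives 130000 nM.
Compound 3, `CC(NC(=O)N(C)S(=O)(=O)c1ccccc1)c1ccccc1OCc1ccccc1`, gives 21700 nM.

All three were tested in a functional assay on thoracic aorta (Rattus norvegicus, strain Wistar), with a stated time of 15 min; a lower number here means that less compound is needed, a higher number that more compound is needed for the effect. Compound 1 and compound 2 share one core and differ by chloro in place of hydrogen on an aromatic carbon. That single change produced a 2.3-fold lower number from compound 2 to compound 1 (0.35 log units; beyond the scatter), a modest shift, but one that lies beyond the usual scatter.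

Compound 3 has the lowest number of the three. Its core is not the same as the core of compound 2, and the difference between the two cores is not broken down here; what is known is that compound 3 sits well below compound 1 and further still below compound 2, both gaps beyond the scatter.

Compound 4, `CC(NC(=O)N(C)S(=O)(=O)c1ccc(Cl)cc1)c1ccccc1OCc1ccccc1`, has not yet been measured. It differs from compound 3 by chloro in place of hydrogen on an aromatic carbon. This is the same change that leads from compound 2 to compound 1, made at the same place, para to a large group, so the earlier step is the natural reference.

On that basis compound 4 is expected to give 9500 nM in this assay, with a plausible range from 4000 nM to 25000 nM. The expected step is a 2.3-fold lower number from compound 3 to compound 4 (0.36 log units; beyond the scatter), and it rests on the single earlier observation that the same change gave a 2.3-fold lower number from compound 2 to compound 1 (0.35 log units; beyond the scatter). For the measured compounds named here, only one such step is known. The range is kept fairly wide, and whether the shift repeats on the core of compound 3 remains to be seen.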

Compound 4, half-maximal effective concentration: 38400 nM
The estimate for compound 4 lay 4.0-fold (0.61 log units) below the measured number; measured number above the stated range.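

In this assay, chloro in place of hydrogen on the second core gave a 1.8-fold higher number from compound 3 to compound 4 (0.25 log units; within the scatter), a step that cannot be told from the usual scatter, so on this core the change shows no clear effect in either direction. For the compounds shown here, the modest shift seen on the first core therefore did not carry over, and the outcome of the change cannot simply be transferred from one core to the other; the two steps differ by more than their scatter allows: the same change on two cores in this assay, a 2.3-fold lower number (0.35 log units; beyond the scatter) from compound 2 to compound 1 and a 1.8-fold higher number (0.25 log units; within the scatter) from compound 3 to compound 4, 4.0-fold (0.60 log units) apart, beyond the scatter of two such steps The result does not show which of the differences between the two cores lies behind this, and with only one pair on each core it cannot say how either step would hold up across further pairs, or whether the same would be seen on a third core.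

The compounds shown leave open how a fluoro, a methoxy or an amine in the same place would behave on either core. Also open, going by these compounds, is whether a longer chain in place of the benzyl group would alter the response to chloro on these two cores.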